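Bromo-to-fluoro exchange on the thioaryl ring: working notes

A few compounds are considered here, and "the series" means these few. Any claim that something is new, unique, unknown or untested is made for them only; others in the source may bear on it.

Measured so far:
compound 1 `CC(O)(CSc1ccc(Br)cc1)c1nc(-c2ccc(F)c(Cl)c2)no1` — 8800 nM
compound 2 `CC(O)(CSc1ccc(F)cc1)c1nc(-c2ccc([N+](=O)[O-])c(C(F)(F)F)c2)no1` — 5100 nM
compound 3 `CC(O)(CSc1ccc(Br)cc1)c1nc(-c2ccc([N+](=O)[O-])c(C(F)(F)F)c2)no1` — 1600 nM

All numbers come from a functional assay on DU-145 cells (Homo sapiens) for cytotoxicity, read by MTT assay; a lower number here means a stronger inhibitor, a higher number a weaker inhibitor. Compound 3 gives the lowest number of the three. Compound 1 and compound 2 lie within the usual scatter of each other, so nothing separates them. Compound 1 and compound 3 differ in more than one place; the difference between the two cores is not broken down here.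

Among the compounds with values here, the one single-point step that is measured is fluoro in place of bromo on an aromatic carbon, which gives a 3.2-fold higher number from compound 3 to compound 2 (0.50 log units; beyond the scatter).

Compound 4 `CC(O)(CSc1ccc(F)cc1)c1nc(-c2ccc(F)c(Cl)c2)no1` has not yet been run. It arises from compound 1 by fluoro in place of bromo on an aromatic carbon. The place of the change reads the same, word for word, as for the measured pair, so this is the same change.

Within the data shown here, the step from compound 1 to compound 4 is expected to be a 2.3-fold higher number from compound 1 to compound 4 (0.36 log units; beyond the scatter), resting on a 3.2-fold higher number from compound 3 to compound 2 (0.50 log units; beyond the scatter) as the only measured instance of this change; a weaker compound such as compound 1 may respond less sharply. Compound 4 is therefore estimated at 20000 nM, expected to fall between 8000 nM and 50000 nM.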

Compound 4, half-maximal inhibitory concentration: 2900 nM
Compound 4: middle estimate off by 6.9-fold (0.84 log units), on the high side; measured number outside the range, below it.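

In this assay, fluoro in place of bromo on an aromatic carbon gives a 3.0-fold lower number from compound 1 to compound 4 (0.48 log units; beyond the scatter). This change therefore does not carry over from one core to the other in this series, not even in direction: the same change on two cores in this assay, a 3.2-fold higher number (0.50 log units; beyond the scatter) from compound 3 to compound 2 and a 3.0-fold lower number (0.48 log units; beyond the scatter) from compound 1 to compound 4, 9.7-fold (0.99 log units) apart, beyond the scatter of two such steps

This does not show why the direction differs, and two pairs give no rule for predicting the outcome on a further core; the cores differ in more than one place, with chloro and fluoro on one and nitro and trifluoromethyl on the other, and these pairs do not say which of those groups matters.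

The compounds shown leave open whether a core carrying nitro alone or trifluoromethyl alone would follow the core of compound 1 or the core of compound 3. They also leave open how chloro or methoxy would read in place of bromo at the same carbon on each core.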